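This account rests on a few compounds, and the source may have more. Where it says the series, first, only, none or still open, it means among the compounds named here.

In a functional assay on KB cells (Homo sapiens) for cytotoxicity (a lower number here means that less compound is needed, a higher number that more compound is needed for the effect), compound 1 `COC1=C(C)C(=O)/C(=C(O)/C=C/c2ccccc2C)C(=O)C1(C)C` gives 4.1 ug/mL and compound 2 `COC1=C(C)C(=O)/C(=C(O)/C=C/c2c(C)cccc2C)C(=O)C1(C)C` gives 7.1 ug/mL. These two values lie within the scatter of each other, and compound 2 has no other measured neighbour to be placed against. The next compound, compound 3 `COC1=C(C)C(=O)/C(=C(O)/C=C/c2ccco2)C(=O)C1(C)C`, carries this change: furan-2-yl in place of 2,6-dimethylphenyl on a double-bonded chain carbon bound to a double-bonded chain carbon. Within the data shown here, only one measured step bears on it, a 1.7-fold higher number from compound 1 to compound 2 (0.24 log units; within the scatter), which adds a methyl group to the aromatic group. That step stays within the scatter, but it never replaces the whole aromatic group, so the data give only weak guidance for furan-2-yl. No shift beyond the scatter is therefore expected in this assay, and the estimated change is a 1.6-fold lower number from compound 2 to compound 3 (0.20 log units; within the scatter). For compound 3 the expected value is 4.5 ug/mL, with an estimated range of 1.5 ug/mL to 13 ug/mL.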

Compound 3, concentration for half-maximal effect: 9.9 ug/mL
Compound 3: middle estimate off by 2.2-fold (0.34 log units), on the low side, and the stated range covers the measured number.
By their numbers in this assay, from the lowest: compounds 1, 2 and 3 (each within the scatter of the next, the first and the last beyond it).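

In this assay, exchanging the whole aromatic group on this chain carbon, 2,6-dimethylphenyl for furan-2-yl, gives a 1.4-fold higher number from compound 2 to compound 3 (0.14 log units; within the scatter) and so stays as small as the earlier methyl step, even though a five-membered ring with a hetero atom replaces a six-membered ring of carbon only. Set against 2-methylphenyl, the same furan-2-yl group gives a 2.4-fold higher number from compound 1 to compound 3 (0.38 log units; beyond the scatter) and is the only step among these compounds that lies beyond the scatter. The position therefore accepts a different aromatic ring with only a small shift in the number, and the size of that shift depends on which of the two phenyl groups serves as the reference.

From the compounds shown here alone, whether plain phenyl, thiophen-2-yl, or a phenyl ring carrying an amine or a carboxylic acid would keep the number in this range remains open. Nothing measured here explains either step.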